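The compounds below may be only part of what the source reports. "The series", "measured", "known", "first", "only" and "open" are said of these compounds alone.

Two compounds share a side chain built from a propylcarbonyl group joined through an amide-type nitrogen and a methylene to a small ring on an aromatic core, and differ in that core. Compound 1 `CCCC(=O)NC[C@@H]1C[C@H]1c1cccc2nc(CC)oc12` gives 0.05 nM in an assay on NIH3T3 cells with melatonin receptor type 1A (Homo sapiens) as the target; on this read-out lower numbers stand for stronger inhibition and higher numbers for weaker inhibition. Compound 2 `CCCC(=O)NC[C@@H]1C[C@H]1c1cccc2c1OC(CCC)N2` gives 0.94 nM in this assay, the higher of the two numbers, a gap beyond the usual scatter, so compound 2 binds less tightly than compound 1 on this read-out.

Compound 3 `CCCC1Nc2cccc([C@@H]3C[C@H]3CNC(=O)NCC)c2O1` keeps the core of compound 2 and alters the side chain: ethylamino in place of propyl on a carbonyl carbon. In plainer terms, the propylcarbonyl becomes an ethylcarbamoyl, turning the amide into a urea that carries one more hydrogen-bond donor. Going by the values given here, no pair of measured compounds shows what this change does here, so its size is uncertain. The step from compound 2 to compound 3 is expected to be a 2.7-fold higher number from compound 2 to compound 3 (0.42 log units; beyond the scatter), a modest weakening that could also turn out to be no change beyond the scatter. Compound 3 is therefore expected to give 2.5 nM in this assay, within a range from 0.5 nM to 12 nM.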

Compound 3, inhibition constant: 3.5 nM
For compound 3 the middle estimate is 1.4-fold (0.15 log units) below the measured one; low and high end bracket the measured number.
By their numbers in this assay, from the lowest: compound 1; then compound 2; then compound 3.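

In this assay, putting ethylamino in place of propyl on a carbonyl carbon gives a 3.7-fold higher number from compound 2 to compound 3 (0.57 log units; beyond the scatter), the first direct reading of this change among these compounds. The step shows that this position of the side chain responds to the exchange, though the loss is modest: the propylcarbonyl can become an ethylcarbamoyl on the core of compound 2 and the number shifts only moderately, even though the entering group carries a hydrogen-bond donor that the leaving group lacks and has the same number of heavy atoms. Nothing available here speaks to why the number rises.

This single step leaves open whether the same exchange would cost about as much on the core of compound 1, where the starting number is far lower. It also leaves open how other groups on that carbonyl carbon would compare, such as propylamino, which keeps the chain length of propyl while adding the nitrogen, or methylamino and butylamino, which would show how the length of the chain on a urea matters.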